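Chloro in place of methoxy on compound 3

The compounds below may be only part of what the source reports. "The series", "measured", "known", "first", "only" and "open" are said of these compounds alone.

In a functional assay on RS4-11 cells (Homo sapiens) for inhibition, read by CCK-8 assay, with a stated time of 48 h, tested at 20 uM (a higher number here means more inhibition of growth at the concentration tested, a lower number less inhibition of growth), compound 3 `COc1ccc(Cc2nnc(NC(=O)/C(C#N)=C/c3ccccc3OS(=O)(=O)c3ccc(OC)cc3)s2)cc1` gives 78% and compound 1 `COc1ccc(S(=O)(=O)Oc2ccccc2/C=C(\C#N)C(=O)Nc2nnc(-c3cccs3)s2)cc1` gives 76% within the scatter of it, while compound 2 `Cc1ccc(S(=O)(=O)Oc2cccc(/C=C(\C#N)C(=O)Nc3nnc(-c4ccccc4)s3)c2)cc1` gives 35% as a clearly lower number. Compound 4 `COc1ccc(Cc2nnc(NC(=O)/C(C#N)=C/c3ccccc3OS(=O)(=O)c3ccc(Cl)cc3)s2)cc1` has chloro in place of methoxy on an aromatic carbon of a six-membered aromatic ring of carbon only, para to a large group, so that (4-methoxyphenyl)sulfonyl becomes (4-chlorophenyl)sulfonyl. The difference chloro in place of methoxy on an aromatic carbon leaves the rest of compound 3 untouched. Among the compounds with values here, the single measured step, a number 2 percentage points higher from compound 1 to compound 3 (within the scatter) and within the scatter, concerns 4-methoxybenzyl in place of thiophen-2-yl and bears only indirectly. Compound 2 differs from compound 3 in more than one place and isolates nothing here. Within the data shown here, no measured step covers this exchange, so no step beyond the scatter is expected. The expected step is a number 4 percentage points lower from compound 3 to compound 4 (within the scatter) in this assay with no firm direction. Compound 4 is estimated at 74% with an expected range from 58% to 88% for now.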

Compound 4, percent growth inhibition at one concentration: 79%
Estimate against measurement, compound 4: 5 percentage points below; low and high end bracket the measured number.
By their numbers in this assay, from the lowest: compound 2; then compounds 1, 3 and 4 (each within the scatter of the next).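

Chloro in place of methoxy on an aromatic carbon, para to a large group, gives a number 1 percentage points higher from compound 3 to compound 4 (within the scatter) in this assay, the first reading of a change at this position. The methoxy oxygen is therefore not required to hold the number at this single concentration: chloro, with one heavy atom and no hydrogen-bond acceptor, serves equally well here in this pair. Nothing available explains this outcome.

Still open, as far as these compounds go, is whether a much larger or charged group at the same place, such as a carboxylic acid, a dimethylamino group or a longer chain like butoxy, would keep the number. Compound 2 differs from these compounds in more than one place, so what lies behind its lower number also remains open.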